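Methyl on the hydroxy oxygen of compound 2

A few compounds are considered here, and "the series" means these few. Any claim that something is new, unique, unknown or untested is made for them only; others in the source may bear on it.

- compound 1 `O=C1OC[C@H](Cc2ccccc2)[C@H]1Cc1ccccc1` gives 77000 nM in a functional assay on HL-60 cells (Homo sapiens) for cytotoxicity, read by WST assay, with a stated time of 48 h; on this read-out higher numbers stand for an effect only at larger amounts of compound and lower numbers for an effect already at smaller amounts
- compound 2 `O=C1OC[C@H](Cc2ccccc2)[C@H]1Cc1ccccc1O` gives 83000 nM in this assay

On these numbers compound 2 (83000 nM) stands level with compound 1 (77000 nM), the pair lying within the scatter, so no order can be read from it. Compound 3 `COc1ccccc1C[C@H]1C(=O)OC[C@@H]1Cc1ccccc1` is still unmeasured and differs from compound 2 in one place (methyl in place of hydrogen on an oxygen on an aromatic ring), methyl in place of hydrogen on an oxygen on an aromatic ring, that is, hydroxy to methoxy. Within the data shown here, the one measured step that bears on this is small (a 1.1-fold higher number from compound 1 to compound 2 (0.03 log units; within the scatter)), lies within the scatter and concerns hydroxy in place of hydrogen on an aromatic carbon. Among the measured compounds shown here, no measured step touches the hydroxy oxygen itself, so this guide is indirect and gives no direction. No step beyond the scatter is therefore expected in this assay in either direction. The expected step is small (a 1.1-fold lower number from compound 2 to compound 3 (0.04 log units; within the scatter)) and stays within the scatter. The estimated value for compound 3 is 75000 nM within an expected range (35000 nM to 150000 nM).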

Compound 3, half-maximal effective concentration: 79000 nM
Compound 3: the middle estimate sits 1.1-fold (0.02 log units) below what was measured, and the stated range covers the measured number.
By their numbers in this assay, from the lowest: compounds 1, 3 and 2 (each within the scatter of the next).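

In this assay the reading on the hydroxy oxygen itself is a 1.1-fold lower number from compound 2 to compound 3 (0.02 log units; within the scatter), so hydroxy and methoxy cannot be told apart at this place on the aromatic ring. Measured against hydrogen on the aromatic carbon, the methoxy group gives a 1.0-fold higher number from compound 1 to compound 3 (0.01 log units; within the scatter), which extends the earlier comparison of hydrogen with hydroxy to a third substituent: hydrogen, hydroxy and methoxy all stand level here, and neither removing the hydroxy hydrogen nor adding the methyl carbon gives a step that can be read in this assay. No available evidence bears on what lies behind this flat result.

The compounds shown leave open whether a different kind of group at this place, such as an amine, a carboxylic acid or a longer chain on the oxygen such as butoxy, would give a step beyond the scatter. They also leave open whether the other aromatic ring of the shared core would respond as flatly to the same hydroxy and methoxy groups.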